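Swapping Trifluoromethoxy for Methylsulfonyl on the Fused Ring

The compounds below may be only part of what the source reports. "The series", "measured", "known", "first", "only" and "open" are said of these compounds alone.

Of the compounds shown here, two sharing one core have been measured so far in a functional assay on HEK293 cells for agonist activity at Free fatty acid receptor 1 (Homo sapiens), read by fluorescence and calcium flux, with a stated time of 10 min; on this read-out lower numbers stand for an effect already at smaller amounts and higher numbers for an effect only at larger amounts of compound. Compound 1 `CC#C[C@@H](CC(=O)O)c1ccc(OC[C@H]2COc3ccc(OC(C)C)cc3O2)cc1` carries an isopropyl group on an oxygen on an aromatic ring, and in this assay compound 1 gives 280 nM. Compound 2 `CC#C[C@@H](CC(=O)O)c1ccc(OC[C@H]2COc3ccc(OC(F)(F)F)cc3O2)cc1` carries a trifluoromethyl group there instead, and in this assay compound 2 gives 700 nM. Among the measured compounds shown here, the single step between them, a 2.5-fold higher number from compound 1 to compound 2 (0.40 log units; beyond the scatter), is the only measured step available. For the measured compounds named here, compound 2 thus stands at the higher of the two numbers, with compound 1 as its only neighbour.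

Compound 3 `CC#C[C@@H](CC(=O)O)c1ccc(OC[C@H]2COc3ccc(S(C)(=O)=O)cc3O2)cc1` differs from compound 2 in one place: methylsulfonyl in place of trifluoromethoxy on an aromatic carbon. Going by the values given here, no measured step covers an exchange of this kind; the one known step, a 2.5-fold higher number from compound 1 to compound 2 (0.40 log units; beyond the scatter), concerns a different pair of groups at the same place and gives only a rough sense that altering this group moves the number modestly. The expected step is a 1.3-fold higher number from compound 2 to compound 3 (0.11 log units; within the scatter). The expected value for compound 3 is 900 nM, within a range from 300 nM to 3000 nM.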

Compound 3, half-maximal effective concentration: 27200 nM
Compound 3: middle estimate off by 30-fold (1.48 log units), on the low side; the measured number lies above the stated range.
By their numbers in this assay, from the lowest: compound 1; then compound 2; then compound 3.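

In this assay this position proves far more sensitive than the earlier pair could show: exchanging isopropoxy for trifluoromethoxy gave a 2.5-fold higher number from compound 1 to compound 2 (0.40 log units; beyond the scatter) while methylsulfonyl in place of trifluoromethoxy on the same aromatic carbon gives a 39-fold higher number from compound 2 to compound 3 (1.59 log units; beyond the scatter) and so a much larger move. Set against isopropoxy, the change gives a 97-fold higher number from compound 1 to compound 3 (1.99 log units; beyond the scatter) and compound 3 has the highest number of the three, with both steps to it printed as beyond the scatter, so the group on this carbon can shift the number over a wide span and not only modestly. Nothing at hand explains why methylsulfonyl differs so sharply from the two groups attached through oxygen.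

The three compounds leave open whether this large rise belongs to methylsulfonyl alone or extends to related groups, and a methylthio group or a sulfonamide on the same aromatic carbon would help to separate those two readings. They also leave open whether a small group such as methoxy or a plain hydrogen at this place would give a number nearer to that of compound 1 or nearer to that of compound 3.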